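Aryl carbonyl variation on the shared core: compound 4

A few compounds are considered here, and "the series" means these few. Any claim that something is new, unique, unknown or untested is made for them only; others in the source may bear on it.

Measured compounds:
compound 1 `CCNC(=O)[C@H]1O[C@@H](n2cnc3c(NNC(=O)c4ccccc4)nc(Cl)nc32)[C@H](O)[C@@H]1O`: in an assay on CHO cells for displacement of a labelled ligand from adenosine receptor A1 (Homo sapiens) (a higher number here means a weaker inhibitor, a lower number a stronger inhibitor), compound 1 gives only the limit > 5000 nM.
compound 2 `CCNC(=O)[C@H]1O[C@@H](n2cnc3c(NNC(=O)c4cccs4)nc(Cl)nc32)[C@H](O)[C@@H]1O`: 737 nM.
compound 3 `CCNC(=O)[C@H]1O[C@@H](n2cnc3c(NNC(=O)c4sccc4C)nc(Cl)nc32)[C@H](O)[C@@H]1O`: 1600 nM.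

Compound 3 holds the highest of the two numbers shown; compound 2 is nearest, and the gap is a 2.2-fold higher number from compound 2 to compound 3 (0.34 log units; beyond the scatter). The entry for compound 1 is a limit, not a number (the limit of > 5000 nM in this assay, at which 1 of the 3 values shown sits).

Compound 4 `CCNC(=O)[C@H]1O[C@@H](n2cnc3c(NNC(=O)c4cc(C)on4)nc(Cl)nc32)[C@H](O)[C@@H]1O` differs from compound 3 by 5-methyl-1,2-oxazol-3-yl in place of 3-methylthiophen-2-yl on a carbonyl carbon. Within the data shown here, no measured step exchanges one five-membered ring for another. The related steps are an at least 6.7-fold lower number from compound 1 to compound 2 (0.83 log units; beyond the scatter) and an at least 3.1-fold lower number from compound 1 to compound 3 (0.49 log units; beyond the scatter), which show the ring on the carbonyl carbon can move the number markedly, and a 2.2-fold higher number from compound 2 to compound 3 (0.34 log units; beyond the scatter), a modest shift from a methyl. Going by these compounds, the direction for a ring with two hetero atoms is unknown. The step of a 1.6-fold higher number from compound 3 to compound 4 (0.19 log units; within the scatter) is therefore expected to be small, with a wide range. Compound 4 is estimated at 2500 nM, between 700 nM and 9000 nM.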

Compound 4, inhibition constant: > 5000 nM
Compound 4: no number, only a limit (the forecaster's own chance of this, stated with the estimate: 30%); at least 2.0-fold (0.30 log units) between middle value and limit.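

Compound 4 gives > 5000 nM in this assay, which is a limit and not a number. The exchange on the carbonyl carbon gives an at least 3.1-fold higher number from compound 3 to compound 4 (0.49 log units; beyond the scatter) and an at least 6.7-fold higher number from compound 2 to compound 4 (0.83 log units; beyond the scatter), so a second hetero atom in the five-membered ring does not keep the readable numbers of the two thiophene compounds, compound 2 and compound 3. The step from compound 1 to compound 4 cannot be read, since both entries are limits.

Open, going by these compounds, is whether the methyl matters on this ring. An unsubstituted 1,2-oxazol-3-yl, a furan-2-yl or a thiophen-2-yl carrying an amine would test how far the thiophene sulfur is needed.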